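Swapping the Chloroethyl Tail for a Vinyl Group

A few compounds are considered here, and "the series" means these few. Any claim that something is new, unique, unknown or untested is made for them only; others in the source may bear on it.

Compound 1 `C#CC(=O)N(Cc1ccc(OC)c(O)c1)c1cc(OC)c(OC)c(OC)c1` gives 310 nM in a functional assay on HCT-116 cells (Homo sapiens) for inhibition, read by MTT assay, with a stated time of 48 h; on this read-out lower numbers stand for stronger inhibition and higher numbers for weaker inhibition.
Compound 2 `COc1ccc(CN(C(=O)CCCl)c2cc(OC)c(OC)c(OC)c2)cc1O` gives 150 nM in this assay.

Compound 2 holds the lowest of the two numbers; the only gap to it is a 2.1-fold lower number from compound 1 to compound 2 (0.32 log units; beyond the scatter). Compound 3 `C=CC(=O)N(Cc1ccc(OC)c(O)c1)c1cc(OC)c(OC)c(OC)c1` differs from compound 2 by vinyl in place of 2-chloroethyl on a carbonyl carbon. Going by the values given here, the single measured step, a 2.1-fold lower number from compound 1 to compound 2 (0.32 log units; beyond the scatter), changed the same carbonyl carbon and was modest, so a swap at this position has so far moved the read-out only a little. Among the compounds with values here, no measured pair shows the vinyl group itself. A small step, likely within the scatter, is therefore expected for compound 3, namely a 1.3-fold higher number from compound 2 to compound 3 (0.12 log units; within the scatter). Compound 3 is estimated at 200 nM, between 80 nM and 500 nM.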

Compound 3, half-maximal inhibitory concentration: 98 nM
For compound 3 the middle estimate is 2.0-fold (0.31 log units) above the measured one; the range from low to high includes it.
By their numbers in this assay, from the lowest: compounds 3 and 2 (each within the scatter of the next); then compound 1.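

At this carbonyl carbon, vinyl and 2-chloroethyl cannot be told apart in this assay, with a 1.5-fold lower number from compound 2 to compound 3 (0.18 log units; within the scatter). Vinyl does separate from ethynyl, with a 3.2-fold lower number from compound 1 to compound 3 (0.50 log units; beyond the scatter), so among these three groups ethynyl alone stands apart. No available evidence explains these steps.

Still open, going by these compounds, is how the read-out would respond to an amine, a carboxylic acid or a longer chain on the same carbonyl carbon. The compounds shown also leave open whether the steps between these three groups would hold with any change elsewhere on the shared core.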